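The source may report more compounds than this note shows. Statements on the series, on what has been measured and on what is new or still open speak of the compounds shown alone.

For the measured compounds named here, in an ADME assay on Vero cells (Chlorocebus sabaeus) for cytotoxicity, with a stated time of 72 h (on this read-out lower numbers stand for stronger inhibition and higher numbers for weaker inhibition), compound 1 `Cc1ccc(CNC(=O)c2c(C)nc3cc(C)ccn23)cc1` gives 54700 nM, the only true number so far. Compound 2 `COc1cccc(CNC(=O)c2c(C)nc3cc(C)ccn23)c1` reads > 128000 nM, which is a limit of the assay and not a number. Compound 3 `Cc1ccn2c(C(=O)NCc3ccc(Cl)cc3)c(C)nc2c1` reads > 128000 nM, which is also a limit. Compound 3 therefore stands at the limit of > 128000 nM in this assay, at which 2 of the 3 values shown sit.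

The next compound, compound 4 `Cc1ccn2c(C(=O)NCc3cccc(F)c3)c(C)nc2c1`, differs from it in one group: 3-fluorophenyl in place of 4-chlorophenyl on a saturated chain carbon bound to an amide-type nitrogen. In words, this is 3-fluorophenyl in place of 4-chlorophenyl on a saturated chain carbon bound to an amide-type nitrogen.

Going by the values given here, only one measured step bears on this swap, an at least 2.3-fold higher number from compound 1 to compound 3 (0.36 log units; beyond the scatter), where the group on the same aromatic ring changes. Two of the three compounds sit at the limit, and compound 1 goes against that pattern. Compound 4 is therefore expected to stay close to compound 3 in this assay, quite possibly at the limit again, with no shift beyond the scatter. The expected change is a step that the limit leaves unreadable from compound 3 to compound 4. For compound 4 the estimate is 130000 nM, with an expected range from 60000 nM to 260000 nM.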

Compound 4, half-maximal inhibitory concentration: > 128000 nM
Compound 4: no number, only a limit; the forecaster's own chance of this, stated with the estimate: 70%; the middle value does not contradict the limit.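

On the saturated chain carbon bound to an amide-type nitrogen, 3-fluorophenyl now joins the groups that leave this assay at its limit, which is a limit of the assay and not a number: the limit of > 128000 nM in this assay, at which 3 of the 4 values shown sit. For the compounds shown here, compound 1, with its 4-methylphenyl group, goes against this pattern as the only compound with a true number, and the swap to 3-fluorophenyl gives an at least 2.3-fold higher number from compound 1 to compound 4 (0.36 log units; beyond the scatter). The steps to compound 4 from compound 2 and from compound 3 cannot be read, as both ends of each are limits.

From the compounds shown here alone, how far compound 2, compound 3 and compound 4 lie from one another remains unknown. Also open, going by these compounds, is how a group carrying an amine or a carboxylic acid would read in this assay at this same place.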